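Ring for chain on the pyridone nitrogen: compound 4

A few compounds are considered here, and "the series" means these few. Any claim that something is new, unique, unknown or untested is made for them only; others in the source may bear on it.

Measured so far:
Compound 1, `CC(C)CCn1ccc(OCc2ccccc2)c(C#N)c1=O`, gives 2950 nM.
Compound 2, `CC(C)CCn1ccc(N2CCC(c3ccccc3)CC2)c(C#N)c1=O`, gives 102 nM.
Compound 3, `CC(C)CCn1ccc(N2CCCCC2)c(C#N)c1=O`, gives 31600 nM.

All three numbers come from a functional assay on CHO cells for positive allosteric modulation of metabotropic glutamate receptor 2 (Homo sapiens), with a stated time of 30 min; a lower number here means that less compound is needed, a higher number that more compound is needed for the effect. Compound 2 has the lowest number of the three; compound 1 stands nearest to it, though beyond the scatter, and compound 3 stands furthest, as the step of a 310-fold higher number from compound 2 to compound 3 (2.49 log units; beyond the scatter) shows. Within the data shown here, that step, hydrogen in place of phenyl on a saturated ring carbon, is the only single-point change among the measured compounds, and it concerns the saturated ring, not the chain on the aromatic nitrogen.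

Compound 4, `N#Cc1c(N2CCC(c3ccccc3)CC2)ccn(CC2CCC2)c1=O`, differs from compound 2 in cyclobutyl in place of isobutyl on a saturated chain carbon bound to an aromatic nitrogen. Among the measured compounds shown here, no measured step touches this chain: compound 1 differs from compound 2 at another place, and compound 3 differs in the saturated ring. What is known is that the saturated ring with its phenyl, kept unchanged in compound 4, carries the large step, while the chain on the aromatic nitrogen is the same in all three measured compounds. The expected step in this assay is therefore none beyond the scatter, in either direction. Compound 4 is estimated at 150 nM, with a range from 50 nM to 450 nM. The step this estimate means is a 1.5-fold higher number from compound 2 to compound 4 (0.17 log units; within the scatter), expected to stay within the scatter.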

Compound 4, half-maximal effective concentration: 55 nM
The estimate for compound 4 lay 2.7-fold (0.44 log units) above the measured number, within the range that was stated.
By their numbers in this assay, from the lowest: compounds 4 and 2 (each within the scatter of the next); then compound 1; then compound 3.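

In this assay, the exchange of isobutyl for cyclobutyl gives a 1.9-fold lower number from compound 2 to compound 4 (0.27 log units; within the scatter), the first step shown that touches the chain on the aromatic nitrogen. At this place, on a saturated chain carbon bound to an aromatic nitrogen, an open isobutyl group and a four-membered non-aromatic ring of carbon only, with the same count of heavy atoms, therefore cannot be told apart in this assay, whereas the earlier step, a 310-fold higher number from compound 2 to compound 3 (2.49 log units; beyond the scatter), concerned the saturated ring and said nothing about this chain. No measurement shown offers an explanation for this result.

On these data alone, one pair of groups of equal heavy-atom count gives only a narrow view of this place, so it remains open how a longer chain, a cyclopentyl ring, or a chain carrying an amine or a carboxylic acid would read here. As far as these compounds go, it also remains open whether the exchange of isobutyl for cyclobutyl would read the same way with the other groups on the core, those of compound 1 and compound 3.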